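Extending the ethyl chain of compound 2 with a triazole

A few compounds are considered here, and "the series" means these few. Any claim that something is new, unique, unknown or untested is made for them only; others in the source may bear on it.

Compound 2 `CCCCNc1nc(N)nc(C)c1CC` sits second highest of the three numbers measured in an assay on HEK293 cells for agonist activity at Toll-like receptor 8 (Homo sapiens), read by spectrophotometry (a higher number here means that more compound is needed for the effect, a lower number that less compound is needed), where compound 2 gives 1660 nM. Compound 1 `CCCCNc1nc(N)nc(C)c1CCCn1c(C)nc2ccccc21` gives 366 nM in this assay, and compound 3 `CCCCNc1nc(N)nc(C)c1C#C[Si](C)(C)C` gives 9240 nM. Compound 4 `CCCCNc1nc(N)nc(C)c1CCCn1cncn1` has not been measured; it differs from compound 2 by (1H-1,2,4-triazol-1-yl)methyl in place of hydrogen on a saturated chain carbon, two bonds along the chain from an aromatic carbon.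

Among the measured compounds shown here, only one measured step changes a single place, a 5.6-fold higher number from compound 2 to compound 3 (0.75 log units; beyond the scatter), and it concerns a different kind of change, a replacement directly on the aromatic carbon rather than a lengthening of the ethyl chain. For the measured compounds named here, compound 1 is closer in kind: its chain also carries an aromatic ring, and its number is lower than that of compound 2, though no single-place step joins the two. Going by the values given here, on that basis a lower number is expected for compound 4, by roughly a 2.8-fold lower number from compound 2 to compound 4 (0.44 log units; beyond the scatter), with wide uncertainty because the one direct step, a 5.6-fold higher number from compound 2 to compound 3 (0.75 log units; beyond the scatter), went the other way. Compound 4 is therefore estimated at 600 nM, between 200 nM and 2000 nM.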

Compound 4, half-maximal effective concentration: 1050 nM
The estimate for compound 4 lay 1.8-fold (0.24 log units) below the measured number; the range from low to high includes it.
By their numbers in this assay, from the lowest: compound 1; then compounds 4 and 2 (each within the scatter of the next); then compound 3.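

In this assay the extension gives a 1.6-fold lower number from compound 2 to compound 4 (0.20 log units; within the scatter) and so (1H-1,2,4-triazol-1-yl)methyl in place of hydrogen on this saturated chain carbon leaves the number within the scatter of that of compound 2. The replacement on the aromatic carbon, by contrast, gives a 5.6-fold higher number from compound 2 to compound 3 (0.75 log units; beyond the scatter) and lies beyond the scatter, though it involves a different group at a different place. Compound 4 gives 1050 nM and compound 1 gives 366 nM with another ring on its chain, so a ring on this chain does not by itself bring the number down to that of compound 1.

Nothing in the data given explains why this change has so small an effect. Open too, from the compounds shown here alone, is how an amine, a carboxylic acid or a plain longer alkyl chain would read at this chain carbon.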